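A few compounds are considered here, and "the series" means these few. Any claim that something is new, unique, unknown or untested is made for them only; others in the source may bear on it.

Compound 1 `Cc1nc(C(NC(=O)C(=O)Nc2ccc(F)c(F)c2)C2CCCCN2)sc1CO` gives > 87000 nM in an ADME assay on MT2 cells (Homo sapiens) for cytotoxicity, read by XTT assay, with a stated time of 4 days; a higher number here means that more compound is tolerated, a lower number that less compound is tolerated; this is a limit of the assay, not a number.
Compound 2 `Cc1nc(C(NC(=O)C(=O)Nc2ccc(Cl)cc2)C2CCCNC2)sc1CCO` gives > 78500 nM in this assay; this too is a limit.
Compound 3 `Cc1nc(C(NC(=O)C(=O)Nc2ccc(Cl)cc2)C2CCNCC2)sc1CCO` gives > 78500 nM in this assay; again a limit.

Compound 1 stands on no measured number in this assay: its value is a limit, and the two further values in the series are limits as well, so no order among the three can be read. Among the measured compounds shown here, the single one-change step in the set, a step that the two limits leave unreadable from compound 2 to compound 3, concerns piperidin-4-yl in place of piperidin-3-yl on the saturated carbon and has no readable size.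

Compound 4 `Cc1nc(C(NC(=O)C(=O)Nc2ccc(F)c(Cl)c2)C2CCCCN2)sc1CO` differs from compound 1 by chloro in place of fluoro on an aromatic carbon. For the measured compounds named here, no measured step changes the aromatic substituent, so none bears directly on this step; what the data offer is the limit of > 78500 nM in this assay, at which 2 of the 3 values shown sit, and (the limit of > 87000 nM in this assay, at which 1 of the 3 values shown sits), which show every tested member tolerated up to the top of the tested range.

The step of a number no higher from compound 1 to compound 4 (the limit leaves the size open) is therefore expected to show no change beyond the scatter, and the result for compound 4 is expected to be another limit rather than a number. Compound 4 is estimated at 87000 nM, within a range from 40000 nM to 200000 nM.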

Compound 4, half-maximal cytotoxic concentration: > 77800 nM
Compound 4: no number, only a limit; the forecaster's own chance of this, stated with the estimate: 85%; the middle value does not contradict the limit.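

In this assay compound 4 gives > 77800 nM, a limit of the assay. Compound 1 gives > 87000 nM, also a limit, so the step between compound 1 and compound 4 cannot be read. The compounds shown leave open the concentration at which any of them reaches half-maximal cytotoxicity, and whether chloro in place of fluoro shifts it.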